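The compounds below may be only part of what the source reports. "The series", "measured", "known", "first", "only" and "open" are said of these compounds alone.

Measured so far in a functional assay on SW-620 cells (Homo sapiens) for antiproliferative activity, read by MTT assay, with a stated time of 24 h; a lower number here means a stronger inhibitor, a higher number a weaker inhibitor:

compound 1, `COc1ccc(/C=C/C(=O)c2ccc(OC)c3c2OC(C)(C)C=C3)c(F)c1`, giving 6570 nM
compound 2, `COc1ccc(C(=O)/C=C/c2cccc([N+](=O)[O-])c2)c2c1C=CC(C)(C)O2`, giving 4090 nM
compound 3, `COc1ccc(C(=O)/C=C/c2ccccc2Cl)c2c1C=CC(C)(C)O2`, reported only as a limit of this assay, > 10000 nM

Compound 1 gives the higher of the two numbers on hand, and compound 2 stands nearest to it, at a 1.6-fold lower number from compound 1 to compound 2 (0.21 log units; within the scatter). Compound 3 sits at the limit of > 10000 nM in this assay, at which 1 of the 3 values shown sits. Compound 4, `COc1ccc(C(=O)/C=C/c2ccc(O)cc2)c2c1C=CC(C)(C)O2`, keeps the core of compound 1 and differs in one place only: 4-hydroxyphenyl in place of 2-fluoro-4-methoxyphenyl on a double-bonded chain carbon bound to a double-bonded chain carbon. Within the data shown here, three measured steps concern the same place. The step of a 1.6-fold lower number from compound 1 to compound 2 (0.21 log units; within the scatter) lies within the scatter; the step of an at least 1.5-fold higher number from compound 1 to compound 3 (0.18 log units; that floor lies within the scatter) gives only a floor that also lies within the scatter; the step of an at least 2.4-fold higher number from compound 2 to compound 3 (0.38 log units; beyond the scatter) lies beyond it. Every aryl exchange so far at this place has therefore either left the number where it was or pushed it past the limit, and nothing measured speaks to 4-hydroxyphenyl in particular. One therefore expects for compound 4 a step from compound 1 that stays within the scatter, a 1.0-fold lower number from compound 1 to compound 4 (0.00 log units; within the scatter), with a real chance that this assay reports only a limit. Compound 4 is estimated at 6500 nM, with a range from 2200 nM to 16000 nM.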

Compound 4, half-maximal inhibitory concentration: > 10000 nM
Compound 4 gave a limit, no number; the forecaster's own chance of this, stated with the estimate: 30%; middle value at least 1.5-fold (0.18 log units) from the limit.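

In this assay compound 4 gives > 10000 nM, which is a limit of the assay and not a number. The change reads as an at least 1.5-fold higher number from compound 1 to compound 4 (0.18 log units; that floor lies within the scatter), so it does not separate the 4-hydroxyphenyl group from the 2-fluoro-4-methoxyphenyl group, whereas the change read as an at least 2.4-fold higher number from compound 2 to compound 4 (0.38 log units; beyond the scatter) does separate it from the 3-nitrophenyl group, and the step between compound 3 and compound 4 cannot be read. The 4-hydroxyphenyl group carries a hydrogen-bond donor where the 2-fluoro-4-methoxyphenyl group carries none, and this exchange is the second at this place on a double-bonded chain carbon to end at the limit rather than at a number, leaving compound 2 as the only exchange from compound 1 that still returns one: the limit of > 10000 nM in this assay, at which 2 of the 4 values shown sit.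

As far as these compounds go, the actual values of compound 3 and compound 4 remain unknown, so these two groups cannot be ranked against each other or placed firmly against compound 1. From the compounds shown here alone, it also stays open whether a 4-aminophenyl group, or a phenyl ring bearing a carboxylic acid, would return a number at this place on the shared core.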